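The source may report more compounds than this note shows. Statements on the series, on what has been measured and on what is new or still open speak of the compounds shown alone.

In a functional assay on ileum for inhibition of histamine H1 receptor (Cavia porcellus) (a higher number here means a weaker inhibitor, a lower number a stronger inhibitor), compound 2 `CCSCCCn1c(N2CCN(C)CC2)nc2ccccc21` gives 530 nM, the lowest of the two numbers seen so far, with compound 1 `CN1CCN(c2nc3ccccc3n2-c2ccccc2)CC1` the nearest at 760 nM. For the measured compounds named here, the one measured step, a 1.4-fold lower number from compound 1 to compound 2 (0.16 log units; within the scatter), exchanged a phenyl on the aromatic nitrogen for a longer flexible chain and left the number essentially where it was. Compound 3 `C#CCOCCn1c(N2CCN(C)CC2)nc2ccccc21` carries yet another chain on that nitrogen: propargyloxy in place of (ethylsulfanyl)methyl on a saturated chain carbon, two bonds along the chain from an aromatic nitrogen. The two chains match in size and each holds one hydrogen-bond acceptor, so the exchange amounts to an oxygen for a sulfur and a triple bond outside aromatic rings for an ethyl. Going by the values given here, no measured step touches this part of the chain, and the only step that exists at all was within the scatter, so there is no basis to expect a large move in either direction. Compound 3 is therefore estimated at 600 nM, with a range from 250 nM to 1500 nM. This expected result means a step of a 1.1-fold higher number from compound 2 to compound 3 (0.05 log units; within the scatter), no change beyond the scatter.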

Compound 3, half-maximal inhibitory concentration: 12 nM
The estimate for compound 3 lay 50-fold (1.70 log units) above the measured number, and the stated range ends above it.
By their numbers in this assay, from the lowest: compound 3; then compounds 2 and 1 (each within the scatter of the next).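

In this assay, the step of a 44-fold lower number from compound 2 to compound 3 (1.65 log units; beyond the scatter) shows that this chain position is far from indifferent to what it carries: propargyloxy in place of (ethylsulfanyl)methyl changes the number sharply, although the group's heavy-atom and hydrogen-bond acceptor counts stay as they were. Measured against phenyl on the aromatic nitrogen, 2-(propargyloxy)ethyl gives a 63-fold lower number from compound 1 to compound 3 (1.80 log units; beyond the scatter) while 3-(ethylsulfanyl)propyl gives only a 1.4-fold lower number from compound 1 to compound 2 (0.16 log units; within the scatter), so exchanging phenyl for an open chain does not by itself bring a large step, and the outcome depends on which chain enters. Nothing measured here accounts for the size of the step.

The exchange brings in the oxygen and the triple bond together, so the compounds shown do not tell which of them goes with the lower number; a 3-ethoxypropyl chain would hold the oxygen without the triple bond, and a 2-(propargylsulfanyl)ethyl chain the triple bond with the sulfur. Also open, going by these compounds, is how the number responds to a longer chain between the aromatic nitrogen and the propargyloxy group.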